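Para-Substituent Swap on the Pendant Phenyl of Compound 1

The compounds below may be only part of what the source reports. "The series", "measured", "known", "first", "only" and "open" are said of these compounds alone.

Measured compounds:
compound 1, `COc1cc(-c2ccnc3cc(-c4ccc(F)cc4)nn23)cc(OC)c1OC`: 4540 nM
compound 2, `COc1cc(-c2ccnc3cc(-c4ccc(Cl)cc4)nn23)cc(OC)c1OC`: 4090 nM
compound 3, `COc1cc(-c2ccnc3cc(-c4ccc(C(F)(F)F)cc4)nn23)cc(OC)c1OC`: 1770 nM

In a functional assay on B16-F0 cells (Mus musculus) for inhibition, read by CCK-8 assay, with a stated time of 48 h (a higher number here means a weaker inhibitor, a lower number a stronger inhibitor), compound 1 gives the highest of the three numbers; compound 2 sits nearest, a 1.1-fold lower number from compound 1 to compound 2 (0.05 log units; within the scatter), and compound 3 furthest, a 2.6-fold lower number from compound 1 to compound 3 (0.41 log units; beyond the scatter).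

Compound 4, `C=Cc1ccc(-c2cc3nccc(-c4cc(OC)c(OC)c(OC)c4)n3n2)cc1`, differs from compound 1 as follows: vinyl in place of fluoro on an aromatic carbon. The two measured steps that bear on it both change the same aromatic carbon: a 1.1-fold lower number from compound 1 to compound 2 (0.05 log units; within the scatter), and a 2.6-fold lower number from compound 1 to compound 3 (0.41 log units; beyond the scatter). A vinyl is, like trifluoromethyl, larger than fluoro, so a modest lowering is expected in this assay, not beyond that seen for compound 3. Compound 4 is therefore estimated at 2800 nM, between 1400 nM and 6000 nM, which means an expected step of a 1.6-fold lower number from compound 1 to compound 4 (0.21 log units; within the scatter).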

Compound 4, half-maximal inhibitory concentration: 788 nM
Compound 4: the middle estimate sits 3.6-fold (0.55 log units) above what was measured, and the stated range ends above it.
By their numbers in this assay, from the lowest: compound 4; then compound 3; then compounds 2 and 1 (each within the scatter of the next).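

In this assay, the aromatic carbon that carries fluoro in compound 1 proves more responsive than the halogen and trifluoromethyl changes suggested: vinyl gives a 5.8-fold lower number from compound 1 to compound 4 (0.76 log units; beyond the scatter) and a 5.2-fold lower number from compound 2 to compound 4 (0.72 log units; beyond the scatter) and still a 2.2-fold lower number from compound 3 to compound 4 (0.35 log units; beyond the scatter). Vinyl therefore gives the lowest number of the four, with all three steps beyond the scatter, so size alone among these groups does not set the order. Nothing measured here accounts for this result. The compounds shown leave open whether the double bond matters, since an ethyl, an ethynyl or a longer alkenyl chain on this carbon could test it. Going by these compounds, how an amine or a carboxylic acid there would compare also remains open.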